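The source may report more compounds than this note shows. Statements on the series, on what has been measured and on what is new or still open speak of the compounds shown alone.

In a functional assay on HL-60 cells (Homo sapiens) for antiproliferative activity, read by MTT assay (a lower number here means a stronger inhibitor, a higher number a weaker inhibitor), compound 2 `O[C@@H]1[C@@H](OCc2ccccc2)[C@H](OCc2ccccc2)[C@@H](COCc2ccccc2)O[C@H]1CC1CCCCC1` gives 4100 nM, the lower of the two numbers in the series, and compound 1 `O[C@@H]1[C@@H](OCc2ccccc2)[C@H](OCc2ccccc2)[C@@H](COCc2ccccc2)O[C@@H]1CC1CCCCC1` gives 17200 nM. Compound 3 `CCCC[C@H]1O[C@H](COCc2ccccc2)[C@@H](OCc2ccccc2)[C@H](OCc2ccccc2)[C@H]1O` gives "not active" (no number reported), so it has no number to set beside them.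

Within the data shown here, the only measured step, a 4.2-fold lower number from compound 1 to compound 2 (0.62 log units; beyond the scatter), is modest and comes with the fact that compounds 1 and 2 differ only in the configuration as drawn. It therefore speaks to configuration, not to the group changed here. Compound 4 `O[C@@H]1[C@@H](OCc2ccccc2)[C@H](OCc2ccccc2)[C@@H](COCc2ccccc2)O[C@H]1CC1CC1` keeps the configuration of compound 2 and carries cyclopropyl in place of cyclohexyl on a saturated chain carbon bound to a saturated ring carbon. Among the measured compounds shown here, no measured step covers this change, so its size is uncertain.

With compound 3 at "not active" (no number reported), a move to a higher number is the cautious expectation, and a result without a number cannot be ruled out. The expected change in this assay is modest, an estimated 2.2-fold higher number from compound 2 to compound 4 (0.34 log units; beyond the scatter). For compound 4 the expected value is 9000 nM, with an estimated range of 3000 nM to 30000 nM.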

Compound 4, half-maximal inhibitory concentration: "not active" (no number reported)
Nothing numeric was reported for compound 4; the estimate stays without a comparison.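

In this assay, among these compounds, compound 4 gives "not active" (no number reported) and so no step from compound 2 to compound 4 can be read; nothing at hand bears on this result. The compounds shown leave open how far cyclopropyl in place of cyclohexyl moves the number.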